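Bromine to Fluorine on a Shared Amide Scaffold: Solubility Outlook

The source may hold more compounds than are shown below. What is called first, only, known or untested is meant among the compounds shown, and "the series" means these compounds.

Three compounds share one core, and all three were tested in a physicochemical assay for solubility; a lower number here means a less soluble compound, a higher number a more soluble compound. Compound 1 `O=C(Nc1nc(-c2cccc(C(F)(F)F)c2F)cs1)c1cnc(N2CCCCC2)c(Cl)c1` returned < 10 ug/mL, which is a limit of the assay rather than a number. Compound 2 `O=C(Nc1nc(-c2cccc(C(F)(F)F)c2F)cs1)c1cnc(N2CCC(C(=O)O)CC2)c(Br)c1` likewise returned < 10 ug/mL, again a limit and not a measured figure. Compound 3 `O=C(Nc1nc(-c2cccc(C(F)(F)F)c2F)cs1)c1ccc(N2CCC(C(=O)O)CC2)c(Cl)c1` also gave < 10 ug/mL, once more a limit. So compound 2 stands where every value shown stands: at the limit of < 10 ug/mL in this assay, at which 3 of the 3 values shown sit, with no number to rank it against the others.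

Compound 4 `O=C(Nc1nc(-c2cccc(C(F)(F)F)c2F)cs1)c1cnc(N2CCC(C(=O)O)CC2)c(F)c1` has not yet been measured. It differs from compound 2 in one place: fluoro in place of bromo on an aromatic carbon.

Within the data shown here, no measured pair in this set shows what such a swap does in this assay. With every comparison anchored at the same limit, the expected outcome is that compound 4 also lands at or near that limit, and any step from compound 2 to compound 4 is expected to stay within the usual scatter; the estimate a step that the limit leaves unreadable from compound 2 to compound 4 reflects that. Compound 4 is therefore estimated at 8 ug/mL, within a range from 2 ug/mL to 30 ug/mL.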

Compound 4, solubility: < 10 ug/mL
Compound 4 was reported as a limit; the forecaster's own chance of this, stated with the estimate: 60%; the middle value does not contradict the limit.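

Compound 2 and compound 4 both sit at a limit of this assay rather than at a number, so the step between them cannot be read: the limit of < 10 ug/mL in this assay, at which 4 of the 4 values shown sit.

The compounds shown leave open whether fluoro in place of bromo on an aromatic carbon changes the read-out of this assay at all.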